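Ethyl in place of bromo: a fourth anilino variant

The source may hold more compounds than are shown below. What is called first, only, known or untested is meant among the compounds shown, and "the series" means these compounds.

Compound 3 `C=CC(=O)Nc1cccc(NC(=O)CSc2nc(Nc3ccc(Br)cc3)c3ccccc3n2)c1` gives 11500 nM in a functional assay on MGC-803 cells (Homo sapiens) for inhibition, read by MTT assay, with a stated time of 72 h (a higher number here means a weaker inhibitor, a lower number a stronger inhibitor), the lowest number among those shown. Compound 1 `C=CC(=O)Nc1cccc(NC(=O)CSc2nc(Nc3ccccc3F)c3ccccc3n2)c1` gives 26100 nM in this assay, and the change is a 2.3-fold lower number from compound 1 to compound 3 (0.36 log units; beyond the scatter). For compound 2 `C=CC(=O)Nc1cccc(NC(=O)CSc2nc(Nc3cccc([N+](=O)[O-])c3)c3ccccc3n2)c1` the reading in this assay is a limit, > 50000 nM. From there the step is an at least 4.3-fold lower number from compound 2 to compound 3 (0.63 log units; beyond the scatter). Compound 4 `C=CC(=O)Nc1cccc(NC(=O)CSc2nc(Nc3ccc(CC)cc3)c3ccccc3n2)c1` carries ethyl in place of bromo on an aromatic carbon. Both measured steps concern the group on the nitrogen on the aromatic ring and both run toward compound 3, yet neither exchanges one group for another at the same place on that ring. For compound 4 the step in this assay is therefore expected to stay within the scatter, estimated at a 1.3-fold higher number from compound 3 to compound 4 (0.12 log units; within the scatter). Compound 4 is expected to give 15000 nM in this assay, between 6000 nM and 40000 nM.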

Compound 4, half-maximal inhibitory concentration: 8010 nM
Compound 4: the middle estimate sits 1.9-fold (0.27 log units) above what was measured, and the stated range covers the measured number.
By their numbers in this assay, from the lowest: compounds 4 and 3 (each within the scatter of the next); then compound 1. At a limit, above all of these: compound 2.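

Ethyl in place of bromo, on an aromatic carbon para to a large group, gives a 1.4-fold lower number from compound 3 to compound 4 (0.16 log units; within the scatter), so the two groups are not told apart in this assay. The 4-ethylphenyl group stands clear of 2-fluorophenyl, with a 3.3-fold lower number from compound 1 to compound 4 (0.51 log units; beyond the scatter). The reading of compound 2 is a limit, so an at least 6.2-fold lower number from compound 2 to compound 4 (0.79 log units; beyond the scatter) is only a floor: the limit of > 50000 nM in this assay, at which 1 of the 4 values shown sits.

For the compounds shown here, only this one exchange at the position can be read, so no trend follows from it. A longer chain, an amine or a carboxylic acid at the same place would show how far the position tolerates change.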